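Aryl swap on the ring nitrogen, carried across two cores

The source may hold more compounds than are shown below. What is called first, only, known or untested is meant among the compounds shown, and "the series" means these compounds.

Compound 1 `CNC(=O)c1cc(Oc2ccc(NC(=O)c3nn(-c4ccccc4OC(F)(F)F)c(=O)cc3C)cc2F)ccn1` and compound 2 `CNC(=O)c1cc(Oc2ccc(NC(=O)c3nn(-c4cccc(F)c4)c(=O)cc3C)cc2F)ccn1` share one core; compound 3 `Cc1cc(=O)n(-c2ccccc2OC(F)(F)F)nc1C(=O)Nc1ccc(Oc2ncnc3sccc23)cc1` and compound 4 `Cc1cc(=O)n(-c2cccc(F)c2)nc1C(=O)Nc1ccc(Oc2ncnc3sccc23)cc1` share another. The difference between the two cores is not broken down here. In a functional assay on MCF7 cells (Homo sapiens) for cytotoxicity, read by MTT assay, with a stated time of 72 h (a higher number here means a weaker inhibitor, a lower number a stronger inhibitor), compound 1 gives only a limit, > 40000 nM (the limit of > 40000 nM in this assay, at which 1 of the 3 values shown sits). In this assay compound 2 gives 6410 nM. The change between them, (3-fluorophenyl in place of 2-(trifluoromethoxy)phenyl on an aromatic nitrogen), made an at least 6.2-fold lower number from compound 1 to compound 2 (0.79 log units; beyond the scatter). In this assay compound 3 gives 11000 nM.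

Compound 4 carries the same change on its core, (3-fluorophenyl in place of 2-(trifluoromethoxy)phenyl on an aromatic nitrogen); the surroundings of the place are the same word for word, so this is the same change. A step of similar size is expected, a 5.5-fold lower number from compound 3 to compound 4 (0.74 log units; beyond the scatter), resting on an at least 6.2-fold lower number from compound 1 to compound 2 (0.79 log units; beyond the scatter), which is itself only a lower bound. Compound 4 is expected to give 2000 nM, between 600 nM and 7000 nM.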

Compound 4, half-maximal inhibitory concentration: 27200 nM
Estimate against measurement, compound 4: 14-fold (1.13 log units) below, and the stated range ends below it.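

In this assay, 3-fluorophenyl in place of 2-(trifluoromethoxy)phenyl gave a 2.5-fold higher number from compound 3 to compound 4 (0.39 log units; beyond the scatter), so this change does not carry in the same direction from the core of compound 1 to the core of compound 3: the same change on two cores in this assay, an at least 6.2-fold lower number (0.79 log units; beyond the scatter) from compound 1 to compound 2 and a 2.5-fold higher number (0.39 log units; beyond the scatter) from compound 3 to compound 4, at least 15-fold (1.18 log units) apart, beyond the scatter of two such steps

Compound 1 gives a limit of the assay and not a number: the limit of > 40000 nM in this assay, at which 1 of the 4 values shown sits.

The two pairs show that the outcome of this change depends on the core in this series, but not what in the cores sets the difference, nor how the change behaves on any further core.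

Open, from the compounds shown here alone, is which part of the cores decides the direction of the step. Also open, going by these compounds, is whether a phenyl ring carrying an amine or a carboxylic acid on the same ring nitrogen would follow either step.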